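The source may hold more compounds than are shown below. What is called first, only, known or untested is meant among the compounds shown, and "the series" means these compounds.

Values in a functional assay on HCT-116 cells (Homo sapiens) for cytotoxicity, read by fluorescence, with a stated time of 72 h; on this read-out lower numbers stand for stronger inhibition and higher numbers for weaker inhibition:
compound 1 `CC(C)c1n[nH]c2c(NCc3ccc(-c4ccccn4)cc3)nc(NCC(C)(C)O)nc12`: 85 nM
compound 2 `CC(C)c1n[nH]c2c(NCc3ccc(-c4ccccn4)cc3)nc(N3CCCCC3CCO)nc12`: 142 nM
compound 3 `CC(C)c1n[nH]c2c(NCc3ccc(-c4ccccn4)cc3)nc(NCC(N)CO)nc12`: 781 nM

Compound 2 has two neighbours on these numbers: a 1.7-fold higher number from compound 1 to compound 2 (0.22 log units; within the scatter), and a 5.5-fold higher number from compound 2 to compound 3 (0.74 log units; beyond the scatter). Next is compound 4 `CC(C)c1n[nH]c2c(NCc3ccc(-c4ccccn4)cc3)nc(NCCN(C)C)nc12`, which differs from compound 2 in one place: (2-(dimethylamino)ethyl)amino in place of 2-(2-hydroxyethyl)piperidin-1-yl on an aromatic carbon. Here (2-(dimethylamino)ethyl)amino stands in place of 2-(2-hydroxyethyl)piperidin-1-yl on an aromatic carbon.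

The second of those steps bears most directly, since there the same 2-(2-hydroxyethyl)piperidin-1-yl also gives way to a group with no ring. The first shows that such an exchange need not move the number beyond the scatter. Open chains also differ among themselves: a 9.2-fold higher number from compound 1 to compound 3 (0.96 log units; beyond the scatter). Within the data shown here, no measured compound carries the (2-(dimethylamino)ethyl)amino group, so the precedent is indirect. A modest rise in the number in this assay is therefore expected, smaller than or similar to the step to compound 3.

The estimated step is a 2.3-fold higher number from compound 2 to compound 4 (0.35 log units; beyond the scatter). The value expected for compound 4 is 320 nM, with an estimated range of 100 nM to 1000 nM.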

Compound 4, half-maximal inhibitory concentration: 390 nM
Compound 4: middle estimate off by 1.2-fold (0.09 log units), on the low side; measured number inside the range.
By their numbers in this assay, from the lowest: compounds 1 and 2 (each within the scatter of the next); then compounds 4 and 3 (each within the scatter of the next).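

In this assay, (2-(dimethylamino)ethyl)amino on this aromatic carbon gives a 2.7-fold higher number from compound 2 to compound 4 (0.44 log units; beyond the scatter) and a 4.6-fold higher number from compound 1 to compound 4 (0.66 log units; beyond the scatter), so the number can climb beyond the scatter even though the leaving and entering groups of the first step have the same counts of hydrogen-bond donors and acceptors. Set against the amino- and hydroxyl-bearing chain, the same group gives a 2.0-fold lower number from compound 3 to compound 4 (0.30 log units; within the scatter), so compounds 3 and 4, the two with a second amine nitrogen in the chain, are not separated in this assay, and both stand beyond the scatter from compounds 1 and 2. No measurement is available that explains these steps.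

Loss of the hydroxyl, presence of the amine and loss of the ring remain unseparated here. A piperidine bearing a dimethylamino group, or a longer (3-(dimethylamino)propyl)amino chain, would help to pull these apart.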